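The source may report more compounds than this note shows. Statements on the series, on what has been measured and on what is new or still open speak of the compounds shown alone.

Measured so far:
compound 1, `COc1ccc(CNC(=O)/C=C/c2coc3cc(O)ccc3c2=O)cc1`, in a functional assay on HeLa cells (Homo sapiens) for inhibition, read by MTT assay, with a stated time of 48 h (a lower number here means a stronger inhibitor, a higher number a weaker inhibitor), gives > 100000 nM, a limit of the assay rather than a number
compound 2, `COc1ccc2c(=O)c(/C=C/C(=O)NCc3cccc(F)c3)coc2c1`, in this assay gives 17600 nM
compound 3, `Cc1ccccc1NC(=O)/C=C/c1coc2cc(O)ccc2c1=O`, in this assay gives 8670 nM

Among the two values that are numbers, compound 2 stands highest. Its nearest neighbour is compound 3, whose number is about two steps of the usual scatter lower, so that gap is beyond the scatter and compound 3 is the stronger inhibitor of the two. Compound 1 supplies only a limit (the limit of > 100000 nM in this assay, at which 1 of the 3 values shown sits), so it cannot be ranked against the others. Among the measured compounds shown here, compound 3 differs from compound 2 in more than one place, so no single step between measured compounds can be read from these three.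

The compound still to be measured is compound 4, `CCOc1ccc(NC(=O)/C=C/c2coc3cc(OC)ccc3c2=O)cc1`. It differs from compound 2 in one place:
4-ethoxyphenyl in place of 3-fluorobenzyl on an amide-type nitrogen

Without a measured step for this change, the expectation rests on the span of the numbers shown. The step from compound 2 to compound 4 is expected to be a 1.8-fold lower number from compound 2 to compound 4 (0.25 log units; within the scatter), a small move toward stronger inhibition that may still lie within the scatter. Compound 4 is therefore estimated at 10000 nM in this assay, with a range from 3000 nM to 40000 nM.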

Compound 4, half-maximal inhibitory concentration: > 100000 nM
Compound 4 ended at the assay's limit; the forecaster's own chance of this, stated with the estimate: 10%; at least 10-fold (1.00 log units) between middle value and limit.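

In this assay, among the compounds shown here, placing 4-ethoxyphenyl instead of 3-fluorobenzyl on the amide-type nitrogen gives an at least 5.6-fold higher number from compound 2 to compound 4 (0.75 log units; beyond the scatter), which means weaker inhibition and is the first measured sign that the group at this nitrogen can matter. The value of compound 4 is a limit and not a number, so this step gives only the smallest possible size of the loss, and the real gap may be larger. Compound 4 is not alone at this limit: the limit of > 100000 nM in this assay, at which 2 of the 4 values shown sit.

The swap changes several things at once: the fluorine leaves, an ethoxy enters and a benzyl becomes a phenyl, so the compounds shown cannot tell which of these carries the loss. Going by these compounds, how a plain benzyl or plain phenyl group on this nitrogen would behave stays open, as does the effect of an amine on that ring.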